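From 3-Methylphenyl to 2-Phenylethenyl on the Amide Carbonyl

The source may report more compounds than this note shows. Statements on the series, on what has been measured and on what is new or still open speak of the compounds shown alone.

Of the compounds shown here, three built on one shared core have been tested in a functional assay on MDA-MB-231 cells (Homo sapiens) for antiproliferative activity, read by MTT assay, with a stated time of 48 h; a lower number here means a stronger inhibitor, a higher number a weaker inhibitor. Compound 1 `O=C(Nc1cc(Sc2ncnc3nc[nH]c23)c(O)c2ccccc12)c1ccc([N+](=O)[O-])cc1` gives only a limit in this assay, > 100000 nM. Compound 3 `O=C(Nc1cc(Sc2nncs2)c(O)c2ccccc12)c1ccc(Cl)cc1` likewise returns only a limit, > 100000 nM. Compound 2 `Cc1cccc(C(=O)Nc2cc(Sc3ncn[nH]3)c(O)c3ccccc23)c1`, the starting point of this account, also gives only a limit in this assay, > 100000 nM. Compound 2 therefore stands nowhere in particular among the numbers shown: every value in the set is a limit, (the limit of > 100000 nM in this assay, at which 3 of the 3 values shown sit), and no step between measured compounds can be read from them.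

Compound 4 `O=C(/C=C/c1ccccc1)Nc1cc(Sc2ncn[nH]2)c(O)c2ccccc12` has not yet been measured. It differs from compound 2 in one place (2-phenylethenyl in place of 3-methylphenyl on a carbonyl carbon). The carbonyl carbon and its amide-type nitrogen are kept, and one six-membered aromatic ring of carbon only gives way to another that carries one double bond outside aromatic rings.

For the measured compounds named here, with no measured step to lean on, the expectation for compound 4 rests only on the three limits, including that of compound 2. The expected step of an at least 1.2-fold lower number from compound 2 to compound 4 (0.09 log units; that floor lies within the scatter) is none beyond the scatter, and most probably this assay will again report only a limit. Compound 4 is therefore estimated at 80000 nM in this assay, within a range from 20000 nM to 300000 nM.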

Compound 4, half-maximal inhibitory concentration: > 100000 nM
Compound 4: a limit, no number; the forecaster's own chance of this, stated with the estimate: 70%; middle value at least 1.2-fold (0.09 log units) away from the limit.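

In this assay compound 4 gives only a limit, > 100000 nM, and not a number. For the compounds shown here, compound 2 also gives only a limit, so no step between compound 2 and compound 4 can be read: the limit of > 100000 nM in this assay, at which 4 of the 4 values shown sit. The compounds shown leave open how 2-phenylethenyl and 3-methylphenyl on the carbonyl carbon compare, and whether any compound on this core gives a measurable value.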